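The source may hold more compounds than are shown below. What is called first, only, known or untested is meant among the compounds shown, and "the series" means these compounds.

Compound 2 `O=C(Nc1nc(-c2ccccc2)cs1)c1ccc(Br)cc1` is the shared core carrying a 4-bromophenyl on the carbonyl carbon. In an assay for displacement of a labelled ligand from adenosine receptor A1 (Rattus norvegicus) (on this read-out lower numbers stand for stronger inhibition and higher numbers for weaker inhibition), compound 2 gives 33 nM. Going by the values given here, that is the lowest of the two numbers measured so far. Among the compounds with values here, its only neighbour, compound 1 `O=C(Nc1nc(-c2ccccc2)cs1)c1cccc(Cl)c1`, gives 86 nM. Between them stands one measured step: a 2.6-fold lower number from compound 1 to compound 2 (0.42 log units; beyond the scatter).

Compound 3 `O=C(Nc1nc(-c2ccccc2)cs1)c1ccc(Cl)cc1` has not yet been measured. It differs from compound 2 by chloro in place of bromo on an aromatic carbon; read one bond further out, that is 4-bromophenyl to 4-chlorophenyl. Within the data shown here, the one measured step, from compound 1 to compound 2, changed both the halogen and where it sits, so it bears only loosely on this exchange, where the halogen keeps its place. Among the measured compounds shown here, no large step is therefore expected in this assay; a step of a 1.5-fold higher number from compound 2 to compound 3 (0.18 log units; within the scatter) toward a slightly higher number is expected. Compound 3 is estimated at 50 nM, within a range of 20 nM to 130 nM.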

Compound 3, inhibition constant: 18 nM
Beside the measured number, compound 3's estimate is 2.8-fold (0.44 log units) above it, outside the stated range (below it).
By their numbers in this assay, from the lowest: compounds 3 and 2 (each within the scatter of the next); then compound 1.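

Exchanging bromo for chloro in the same place on the ring in this assay stays within the usual scatter (a 1.8-fold lower number from compound 2 to compound 3 (0.26 log units; within the scatter)), so these two halogens cannot be told apart at this position. Moving the chlorine while keeping the same halogen gives a step beyond the scatter (a 4.8-fold lower number from compound 1 to compound 3 (0.68 log units; beyond the scatter)), which separates what the earlier step had mixed: among these three compounds, where the halogen sits matters more than which halogen it is. No measurement at hand explains why the 4-chlorophenyl and 3-chlorophenyl compounds differ.

The compounds shown carry only halogens on this ring, so it remains open whether the trend would hold with a methoxy group, an amine or a carboxylic acid in the same place. On these data alone, how the unsubstituted phenyl would compare also remains open.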